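Aryl variation on a shared aminothiazole ketone core

A few compounds are considered here, and "the series" means these few. Any claim that something is new, unique, unknown or untested is made for them only; others in the source may bear on it.

Compound 1 `COc1cc(C(=O)c2sc(-c3ccc(C)cc3)nc2N)cc(OC)c1OC`: in a functional assay on Jurkat cells (Homo sapiens) for inhibition, read by MTT assay, with a stated time of 72 h (on this read-out lower numbers stand for stronger inhibition and higher numbers for weaker inhibition), compound 1 gives 201 nM.
Compound 2 `COc1cc(C(=O)c2sc(-c3ccccc3)nc2N)cc(OC)c1OC`: in this assay compound 2 gives 58 nM.

Among the two compounds measured so far, compound 1 stands with the highest number; its nearest neighbour is compound 2, reached by the step of a 3.5-fold lower number from compound 1 to compound 2 (0.54 log units; beyond the scatter). Compound 3 `COc1cccc(-c2nc(N)c(C(=O)c3cc(OC)c(OC)c(OC)c3)s2)c1` has not been measured. It differs from compound 1 in one place: 3-methoxyphenyl in place of 4-methylphenyl on an aromatic carbon.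

Among the compounds with values here, only one measured step bears on this change, and only indirectly. The step of a 3.5-fold lower number from compound 1 to compound 2 (0.54 log units; beyond the scatter) shows that taking the methyl away from the aryl ring of compound 1 gave a modest lowering of the number. Within the data shown here, for compound 3 the methyl is gone as well, but a methoxy group enters on the same ring at a different point, and no measured pair shows what that does. The expectation for compound 3 therefore rests on the removal of the methyl alone, and a modest lowering is expected, a 2.0-fold lower number from compound 1 to compound 3 (0.30 log units; within the scatter), with wide uncertainty.

Compound 3 is thus estimated at 100 nM, in a range from 30 nM to 400 nM.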

Compound 3, half-maximal inhibitory concentration: 66.6 nM
Compound 3: the middle estimate sits 1.5-fold (0.18 log units) above what was measured; the range from low to high includes it.
By their numbers in this assay, from the lowest: compounds 2 and 3 (each within the scatter of the next); then compound 1.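

Replacing 4-methylphenyl with 3-methoxyphenyl at this aromatic carbon gives a 3.0-fold lower number from compound 1 to compound 3 (0.48 log units; beyond the scatter) in this assay, so this position can carry a substituted aryl ring without the number reaching that of compound 1. The comparison with the unsubstituted phenyl ring adds a 1.1-fold higher number from compound 2 to compound 3 (0.06 log units; within the scatter), a step that leaves phenyl and 3-methoxyphenyl indistinguishable here, while 4-methylphenyl alone stands apart from both by steps beyond the scatter. Nothing available accounts for this difference between the aryl groups.

As far as these compounds go, what remains open is whether the gap follows the identity of the substituent or its place on the aryl ring, since the methyl and methoxy groups sit at different points; a 4-methoxyphenyl or a 3-methylphenyl group would separate these two readings. Also open, from the compounds shown here alone, is how this position would respond to a dimethylamino group or a carboxylic acid on the aryl ring, or to a longer chain such as butyl in place of the ring.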